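This account rests on a few compounds, and the source may have more. Where it says the series, first, only, none or still open, it means among the compounds named here.

Measured so far:
compound 1 `COc1ccc(/C=C/C(=O)c2ccc3c(c2)CN(c2ccc(OC)cc2)CO3)cc1` — 61.2%
compound 2 `Cc1ccc(N2COc3ccc(C(=O)/C=C/c4ccccc4Cl)cc3C2)cc1` — 60.4%

Two compounds of the series have numbers in a functional assay on the whole organism (strain Wistar) for inhibition, with Rattus norvegicus as the target, read by paw edema, with a stated time of 3 h, at a dose of 20 mg/kg by the oral route; a lower number here means less inhibition, a higher number more inhibition at the dose given (going by the name of the read-out). In this assay compound 1 gives 61.2% and compound 2 gives 60.4%. Compound 2 has the lower of the two numbers, but its nearest neighbour is compound 1, whose number sits higher by an amount within the scatter, so nothing can be said about order between them. Among the measured compounds shown here, no step between measured compounds that differ in one place is available.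

Compound 3 `COc1ccc(/C=C/C(=O)c2ccc3c(c2)CN(c2ccc(C)cc2)CO3)cc1` has not yet been measured in this assay. It differs from compound 2 in one place: 4-methoxyphenyl in place of 2-chlorophenyl on a double-bonded chain carbon bound to a double-bonded chain carbon. Since compound 1 already carries 4-methoxyphenyl on the chain and gives 61.2%, a step of no size beyond the scatter is expected from compound 2 to compound 3, in either direction. Compound 3 is estimated at 61%, in the range 50% to 72%, which means an expected step of a number 0.6 percentage points higher from compound 2 to compound 3 (within the scatter).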

Compound 3, a percentage reported as inhibition, in the whole organism at one dose (the size of the read-out at that dose, not a potency): 70.4%
The estimate for compound 3 lay 9.4 percentage points below the measured number; the measured number falls inside the stated range.
By their numbers in this assay, from the lowest: compounds 2, 1 and 3 (each within the scatter of the next).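

In this assay, among the compounds shown here, the exchange of 2-chlorophenyl for 4-methoxyphenyl on a double-bonded chain carbon bound to a double-bonded chain carbon gives a number 10 percentage points higher from compound 2 to compound 3 (within the scatter) and so gives the first reading at this position, which does not separate the two groups. The series also gains a second position: methyl in place of methoxy on an aromatic carbon gives a number 9.2 percentage points higher from compound 1 to compound 3 (within the scatter) and likewise does not separate the two groups.

Still open, going by these compounds, is whether an aminophenyl or a carboxyphenyl in place of 4-methoxyphenyl at the chain position would give a step beyond the scatter. Also open, on these data alone, is whether an ethyl or a longer alkyl chain in place of methyl on the aromatic carbon would do so.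

Nothing on hand speaks to what lies behind either step.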